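This account rests on a few compounds, and the source may have more. Where it says the series, first, only, none or still open, it means among the compounds named here.

Values measured in a functional assay on A549 cells (Homo sapiens) for antiproliferative activity, read by MTT assay, with a stated time of 72 h; on this read-out higher numbers stand for weaker inhibition and lower numbers for stronger inhibition:

Compound 1 `O=C(Nc1ccc(Nc2nccc(NC3CCCC3)n2)cc1)Nc1ccc(Cl)c(C(F)(F)F)c1`: 5880 nM
Compound 2 `O=C(Nc1ccc(Nc2nccc(NC3CC3)n2)cc1)Nc1ccc(Cl)c(C(F)(F)F)c1`: 18500 nM
Compound 3 `O=C(Nc1ccc(Nc2nccc(Nc3cccc(Cl)c3)n2)cc1)Nc1ccc(Cl)c(C(F)(F)F)c1`: 8050 nM

Compound 3, at 8050 nM, sits among these three as follows. The comparison with its cyclopentyl partner gives a 1.4-fold higher number from compound 1 to compound 3 (0.14 log units; within the scatter), so those two cannot be told apart. The comparison with its cyclopropyl partner gives a 2.3-fold lower number from compound 2 to compound 3 (0.36 log units; beyond the scatter), a modest but real gap.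

The next compound is compound 4 `O=C(Nc1ccc(Nc2nccc(Nc3ccc(Cl)cc3)n2)cc1)Nc1ccc(Cl)c(C(F)(F)F)c1`. It carries 4-chlorophenyl in place of 3-chlorophenyl on a nitrogen on an aromatic ring. The two have the same atoms, joined differently.

Among the compounds with values here, no measured step makes this exact kind of swap, so the evidence is indirect. Within the data shown here, the steps so far replace the whole group on that nitrogen. Even so, they are small: the largest is a 3.1-fold higher number from compound 1 to compound 2 (0.50 log units; beyond the scatter), and the change from cyclopentyl to 3-chlorophenyl gave only a 1.4-fold higher number from compound 1 to compound 3 (0.14 log units; within the scatter). A change that keeps the same atoms therefore seems unlikely to do more than these, and no shift beyond the scatter is expected in this assay.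

The expected step is a 1.1-fold lower number from compound 3 to compound 4 (0.03 log units; within the scatter).

For compound 4 the estimated value is 7500 nM, with an expected range from 3500 nM to 16000 nM.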

Compound 4, half-maximal inhibitory concentration: 6320 nM
Compound 4: middle estimate off by 1.2-fold (0.07 log units), on the high side, within the range that was stated.
By their numbers in this assay, from the lowest: compounds 1, 4 and 3 (each within the scatter of the next); then compound 2.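

In this assay, within the data shown here, this is the first comparison that keeps a chlorophenyl on the nitrogen and alters only where the chlorine sits on that ring, and the 3-chlorophenyl and 4-chlorophenyl forms cannot be told apart (a 1.3-fold lower number from compound 3 to compound 4 (0.11 log units; within the scatter)). The 4-chlorophenyl group also cannot be told apart from cyclopentyl (a 1.1-fold higher number from compound 1 to compound 4 (0.03 log units; within the scatter)), yet it stands clearly apart from cyclopropyl (a 2.9-fold lower number from compound 2 to compound 4 (0.47 log units; beyond the scatter)), so compounds 1, 3 and 4 now form one cluster within the scatter, with compound 2 the only one separated from the rest. Nothing measured here goes beyond these cell-growth numbers to account for that grouping.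

The compounds shown leave open whether the chlorine matters at all, since a plain phenyl on the same nitrogen, or a phenyl carrying a methoxy group or an amine, could reveal whether this position responds to anything beyond the size of the group. From the compounds shown here alone, it also remains open whether a longer open chain on that nitrogen would fall with the cluster or with compound 2.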